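The source may report more compounds than this note shows. Statements on the series, on what has been measured and on what is new or still open speak of the compounds shown alone.

Among the measured compounds shown here, compound 1 `NS(=O)(=O)CC(=O)NCCSc1nonc1/C(=N/O)Nc1ccc(F)c(C(F)F)c1` gives 73 nM in an assay for inhibition of Indoleamine 2,3-dioxygenase 1 (Homo sapiens), read by fluorescence, with a stated time of 1 h (on this read-out higher numbers stand for weaker inhibition and lower numbers for stronger inhibition), the lower of the two numbers measured so far. Compound 2 `CC1(C(=O)NCCSc2nonc2/C(=N/O)Nc2ccc(F)c(C(F)F)c2)CCN1`, which carries a different group on the carbonyl carbon, gives 360 nM in this assay, a change of a 4.9-fold higher number from compound 1 to compound 2 (0.69 log units; beyond the scatter). Compound 3 `NS(=O)(=O)CC(=O)NCCSc1nonc1/C(=N/O)Nc1cccc(Br)c1` differs from compound 1 at another position: 3-bromophenyl in place of 3-(difluoromethyl)-4-fluorophenyl on an amine nitrogen. For the measured compounds named here, the one measured step concerns the carbonyl side of the molecule and so offers no direct guide for this change to the aromatic ring. A modest weakening is expected, with compound 3 estimated at 160 nM (range 50 nM to 500 nM), which would be a step of a 2.2-fold higher number from compound 1 to compound 3 (0.34 log units; beyond the scatter).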

Compound 3, half-maximal inhibitory concentration: 30 nM
Compound 3: the middle estimate sits 5.3-fold (0.73 log units) above what was measured; measured number outside the range, below it.
By their numbers in this assay, from the lowest: compound 3; then compound 1; then compound 2.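

Among the compounds shown here, this is the first measured step at the aryl group on the amine nitrogen, and in this assay it gives a 2.4-fold lower number from compound 1 to compound 3 (0.39 log units; beyond the scatter). So the difluoromethyl and fluorine substituents of compound 1 are not needed for a low number here, and 3-bromophenyl serves better. Nothing at hand explains this gain. As far as these compounds go, it remains open whether the bromine itself matters, or whether a plain phenyl, 3-chlorophenyl or 3-methylphenyl group would give a similar number. From the compounds shown here alone, it is also open whether the difference between compound 1 and compound 2 at the carbonyl carbon would persist with 3-bromophenyl in place.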